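Carboxy for isopropyl on the phenoxy ring of compound 3

This account rests on a few compounds, and the source may have more. Where it says the series, first, only, none or still open, it means among the compounds named here.

Measured compounds:
compound 1, `CCc1ccc(OCC(=O)N(CC)Cc2cccs2)cc1`: 67 nM
compound 2, `CCN(Cc1cccs1)C(=O)COc1ccccc1`: 1400 nM
compound 3, `CCN(Cc1cccs1)C(=O)COc1ccc(C(C)C)cc1`: 397 nM

All three numbers come from an assay on HEK293 cells for agonist activity at transient receptor potential cation channel subfamily M member 8 (Homo sapiens), read by fluorescence and calcium flux, with a stated time of 15 min; on this read-out higher numbers stand for an effect only at larger amounts of compound and lower numbers for an effect already at smaller amounts. Compound 3 stands second highest of the three: compound 2 is its nearest neighbour, a 3.5-fold lower number from compound 2 to compound 3 (0.55 log units; beyond the scatter), and compound 1 its furthest, a 5.9-fold higher number from compound 1 to compound 3 (0.77 log units; beyond the scatter).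

The next compound is compound 4, `CCN(Cc1cccs1)C(=O)COc1ccc(C(=O)O)cc1`. Its change from compound 3 is carboxy in place of isopropyl on an aromatic carbon.

Among the compounds with values here, two measured steps touch the same aromatic carbon. Removing the ethyl there gave a 21-fold higher number from compound 1 to compound 2 (1.32 log units; beyond the scatter), and adding the isopropyl gave a 3.5-fold lower number from compound 2 to compound 3 (0.55 log units; beyond the scatter), so on this ring a bare hydrogen at that position is the weakest case seen. Nothing measured carries a carboxy, or any group with a hydrogen-bond donor or acceptor, at that position; the data say only that losing the isopropyl costs a modest step. Going by these compounds, compound 4 is therefore expected to give a higher number than compound 3, likely at or beyond the level of compound 2, with wide uncertainty because the entering group is untested.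

Estimate for compound 4 in this assay: 4000 nM, range 1000 nM to 20000 nM, meaning an expected step of a 10-fold higher number from compound 3 to compound 4 (1.00 log units; beyond the scatter).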

Compound 4, half-maximal effective concentration: "not active" (no number reported)
No number was reported for compound 4; the estimate stays without a comparison.
By their numbers in this assay, from the lowest: compound 1; then compound 3; then compound 2.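

Within the data shown here, compound 4 is reported as "not active" in this assay without a number, so no step from compound 3 to compound 4 can be read. No measurement shown bears on this result. The compounds shown leave open whether other groups with a hydrogen-bond donor on that aromatic carbon would give a number.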